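From fluoro to sulfo on a weak growth inhibitor

The source may hold more compounds than are shown below. What is called first, only, known or untested is meant among the compounds shown, and "the series" means these compounds.

Of the compounds shown here, three on a shared core have been tested in a functional assay on L929 cells (Mus musculus) for inhibition; a higher number here means a weaker inhibitor of growth, a lower number a stronger inhibitor of growth. Compound 1 `Nc1nn2c(O)cc(-c3cc([N+](=O)[O-])c(Cl)cc3Cl)nc2c1[N+](=O)[O-]` reaches only a limit of the assay, > 50 ug/mL. Compound 2 `Nc1nn2c(O)cc(-c3ccc(F)cc3)nc2c1[N+](=O)[O-]` likewise reaches a limit, > 50 ug/mL. Compound 3 `Nc1nn2c(O)cc(CNNc3ccc(F)cc3)nc2c1[N+](=O)[O-]` is the single compound with a number, 41.4 ug/mL, and so stands alone among the shown results. The other two values sit at the limit of > 50 ug/mL in this assay, at which 2 of the 3 values shown sit. Compound 4 `Nc1nn2c(O)cc(CNNc3ccc(S(=O)(=O)O)cc3)nc2c1[N+](=O)[O-]` is not yet measured; it differs from compound 3 by sulfo in place of fluoro on an aromatic carbon. Among the measured compounds shown here, no step between measured compounds exists to guide the size of this change, so a step of a 1.4-fold higher number from compound 3 to compound 4 (0.16 log units; within the scatter) is expected, either within the scatter or towards weaker inhibition. Compound 4 is estimated at 60 ug/mL in this assay, between 25 ug/mL and 150 ug/mL, with a real chance that only a limit is reported.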

Compound 4, concentration for 50% growth inhibition: > 50 ug/mL
Compound 4: no number, only a limit; the forecaster's own chance of this, stated with the estimate: 65%; the middle value lies beyond the limit too.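

Sulfo in place of fluoro, on an aromatic carbon para to a large group, gives the first step in this assay between two compounds that differ in one place: an at least 1.2-fold higher number from compound 3 to compound 4 (0.08 log units; that floor lies within the scatter). Compound 4 gives only a limit, so this step is a floor, and that floor alone shows no real loss of growth inhibition. Compound 3 remains the only compound with a number, as most results here stop at the same limit: the limit of > 50 ug/mL in this assay, at which 3 of the 4 values shown sit.

On these data alone, it remains open whether another group at this position, such as an amine or a carboxylic acid, would give a number clearly apart from that of compound 3. As far as these compounds go, with a single number, the true size of the change from fluoro to sulfo also stays unknown.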